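A methoxy group on compound 2

The source may hold more compounds than are shown below. What is called first, only, known or untested is meant among the compounds shown, and "the series" means these compounds.

Measured so far in a functional assay on A549 cells (Homo sapiens) for antiproliferative activity, read by MTT assay, with a stated time of 48 h; on this read-out higher numbers stand for weaker inhibition and lower numbers for stronger inhibition:
Compound 1 `Cc1cc2nc(NC(c3cn(-c4ccccc4)nc3-c3ccc([N+](=O)[O-])cc3)c3c(O)ccc4ccccc34)sc2cc1C` gives 41900 nM
Compound 2 `O=[N+]([O-])c1ccc(-c2nn(-c3ccccc3)cc2C(Nc2nc3ccccc3s2)c2c(O)ccc3ccccc23)cc1` gives 41300 nM

Within the data shown here, compound 2 stands level with the only other measured compound, and the step of a 1.0-fold lower number from compound 1 to compound 2 (0.01 log units; within the scatter) lies within the scatter. Compound 3 `COc1ccc2nc(NC(c3cn(-c4ccccc4)nc3-c3ccc([N+](=O)[O-])cc3)c3c(O)ccc4ccccc34)sc2c1` has not yet been measured and differs from compound 2 by a single change methoxy in place of hydrogen on an aromatic carbon in which methoxy replaces hydrogen on an aromatic carbon, so that 1,3-benzothiazol-2-yl becomes 6-methoxy-1,3-benzothiazol-2-yl. Among the measured compounds shown here, the one measured step that bears on this is the exchange of 5,6-dimethyl-1,3-benzothiazol-2-yl for 1,3-benzothiazol-2-yl, and that step a 1.0-fold lower number from compound 1 to compound 2 (0.01 log units; within the scatter) stayed within the scatter and points in no direction. For the measured compounds named here, no methoxy compound has been measured yet, so this evidence is thin. A step beyond the scatter is therefore not expected in this assay and no direction can be argued. The expected step of a 1.0-fold lower number from compound 2 to compound 3 (0.01 log units; within the scatter) is an estimate that stays within the scatter. For compound 3 the estimated value is 40000 nM with 18000 nM to 85000 nM as the expected range.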

Compound 3, half-maximal inhibitory concentration: 22500 nM
The estimate for compound 3 lay 1.8-fold (0.25 log units) above the measured number; measured number inside the range.
By their numbers in this assay, from the lowest: compounds 3, 2 and 1 (each within the scatter of the next).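

Placing a methoxy on this aromatic carbon, meta to one fused ring and para to another, gives the first reading for an oxygen-bearing group on the 1,3-benzothiazol-2-yl unit, and in this assay the step stays inside the scatter (a 1.8-fold lower number from compound 2 to compound 3 (0.26 log units; within the scatter)). The exchange of 5,6-dimethyl-1,3-benzothiazol-2-yl for 6-methoxy-1,3-benzothiazol-2-yl on the amine nitrogen also stays inside it (a 1.9-fold lower number from compound 1 to compound 3 (0.27 log units; within the scatter)), so the three substitution patterns shown cannot be told apart in this antiproliferative read-out, and neither the methoxy nor the pair of methyl groups separates from the unsubstituted compound 2. Nothing at hand offers an explanation for these numbers, and the small differences among them call for none.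

From the compounds shown here alone, whether a chlorine atom, an amine, a carboxylic acid or a longer chain such as ethoxy on the same aromatic carbon would give a step beyond the scatter remains open. Also open, going by these compounds, is whether any change outside this group, on the rest of the shared core, would move the number further than these three compounds do.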